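Methyl in Place of Hydrogen: Expecting Little Change

This account rests on a few compounds, and the source may have more. Where it says the series, first, only, none or still open, it means among the compounds named here.

Compound 1, `O=C(NOCc1ccccc1)c1cn(-c2ccccc2)nc1-c1ccccc1`, gives 5000 nM in a functional assay on A549 cells (Homo sapiens) for antiproliferative activity, read by MTT assay, with a stated time of 48 h, in the presence of a further agent that is not named here; a lower number here means a stronger inhibitor of growth, a higher number a weaker inhibitor of growth.
Compound 2, `O=C(NOCc1ccccc1F)c1cn(-c2ccccc2)nc1-c1ccccc1`, gives 5940 nM in this assay.
Compound 3, `O=C(NOCc1ccccc1Cl)c1cn(-c2ccccc2)nc1-c1ccccc1`, gives 10300 nM in this assay.

Among these three, compound 1 has the lowest number. Its nearest neighbour is compound 2, with a 1.2-fold higher number from compound 1 to compound 2 (0.07 log units; within the scatter), a step within the scatter. Its furthest is compound 3, with a 2.1-fold higher number from compound 1 to compound 3 (0.31 log units; beyond the scatter), a modest step beyond the scatter. From compound 2 to compound 3 the change is a 1.7-fold higher number from compound 2 to compound 3 (0.24 log units; within the scatter).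

Compound 4, `Cc1ccc(-c2nn(-c3ccccc3)cc2C(=O)NOCc2ccccc2)cc1`, differs from compound 1 by methyl in place of hydrogen on an aromatic carbon. Among the measured compounds shown here, the two measured steps each replace a hydrogen on an aromatic carbon with a halogen, and each does so at a different place in the molecule from the one altered in compound 4; neither introduces a methyl. For the measured compounds named here, no measured step therefore bears directly on this change. What the data show is that small additions on an aromatic carbon moved the number only slightly, and in one case modestly upward. In this assay compound 4 is therefore expected to show a 1.1-fold higher number from compound 1 to compound 4 (0.04 log units; within the scatter), no step beyond the scatter. Compound 4 is estimated at 5500 nM, with a range from 2200 nM to 14000 nM.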

Compound 4, concentration for 50% growth inhibition: 1140 nM
Compound 4: middle estimate off by 4.8-fold (0.68 log units), on the high side, outside the stated range (below it).
By their numbers in this assay, from the lowest: compound 4; then compounds 1, 2 and 3 (each within the scatter of the next, the first and the last beyond it).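

Going from phenyl to 4-methylphenyl gives a 4.4-fold lower number from compound 1 to compound 4 (0.64 log units; beyond the scatter) in this assay and it is the only step shown so far that lowers the number. A single methyl on an aromatic carbon, para to a large group, is therefore enough to strengthen growth inhibition, whereas the chloro step, made at a different place in the molecule, went the opposite way. Nothing measured here explains this step.

As far as these compounds go, it remains open whether the effect belongs to methyl alone or would also appear with an ethyl chain, a methoxy group or an amine at the same place. From the compounds shown here alone, it is equally open whether a methyl on another aromatic ring of the core of compound 1 would lower the number as well.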